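The compounds below may be only part of what the source reports. "The series", "measured", "known", "first", "only" and "open" are said of these compounds alone.

Measured compounds in a functional assay on MCF7 cells (Homo sapiens) for cytotoxicity, read by sulforhodamine B assay, with a stated time of 48 h; a lower number here means a stronger inhibitor of growth, a higher number a weaker inhibitor of growth:

Compound 1 `COc1cc(/C(Cl)=C/C=C(\C#N)C(=O)c2c[nH]c3ccccc23)cc(OC)c1OC` gives 4000 nM in this assay.
Compound 2 `N#C/C(=C\C=C(/Cl)c1ccc(Br)cc1)C(=O)c1c[nH]c2ccccc12` gives 72500 nM in this assay.
Compound 3 `COc1cc(/C(Cl)=C/C=C(\C#N)C(=O)c2c(C)[nH]c3ccccc23)cc(OC)c1OC` gives a value that is a limit of the assay, < 100 nM, in this assay.

Compounds 1 and 3 share a core and differ in one place, (methyl in place of hydrogen on an aromatic carbon). That single change produced an at least 40-fold lower number from compound 1 to compound 3 (1.60 log units; beyond the scatter) in this assay; the size of the step is open-ended, since the value of compound 3 is the limit of < 100 nM in this assay, at which 1 of the 3 values shown sits. Compound 2 differs from compound 1 in more than one place, and the difference between the two cores is not broken down here. Of the two numbers given, compound 2 stands highest, and its nearest neighbour is compound 1.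

Compound 4 `Cc1[nH]c2ccccc2c1C(=O)/C(C#N)=C/C=C(\Cl)c1ccc(Br)cc1` has not yet been measured in this assay. It stands to compound 2 as compound 3 stands to compound 1: the difference is methyl in place of hydrogen on an aromatic carbon, and the place of the change is described in the same words for both pairs, so it is the same change. The expectation for compound 4 rests on that one measured step, an at least 40-fold lower number from compound 1 to compound 3 (1.60 log units; beyond the scatter), applied to the value of compound 2, 72500 nM; from compound 2 to compound 4 a step of about a 36-fold lower number from compound 2 to compound 4 (1.56 log units; beyond the scatter) is expected in this assay. Compound 4 is therefore estimated at 2000 nM in this assay, with a plausible range from 300 nM to 15000 nM.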

Compound 4, concentration for 50% growth inhibition: 73900 nM
Compound 4: middle estimate off by 37-fold (1.57 log units), on the low side, outside the stated range (above it).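

In this assay, methyl in place of hydrogen on an aromatic carbon gave a 1.0-fold higher number from compound 2 to compound 4 (0.01 log units; within the scatter), so on this core compound 2 and compound 4 cannot be told apart. The result of this change on one core therefore did not carry over to the other in this series: the same change on two cores in this assay, an at least 40-fold lower number (1.60 log units; beyond the scatter) from compound 1 to compound 3 and a 1.0-fold higher number (0.01 log units; within the scatter) from compound 2 to compound 4, at least 40-fold (1.61 log units) apart, beyond the scatter of two such steps These two pairs do not show which of the several differences between the two cores goes with the divergent outcome, and the earlier step remains open-ended, the value of compound 3 being a limit of the assay: the limit of < 100 nM in this assay, at which 1 of the 4 values shown sits.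

The compounds shown leave open how a core carrying only some of the differences between compound 1 and compound 2 would respond to the same methyl, and so whether its step would resemble that seen on the core of compound 1 or that seen on the core of compound 2. They also leave open what an ethyl group, a longer chain or an amine would do in the same place, on the aromatic carbon next to the ring nitrogen, on either core.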